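A few compounds are considered here, and "the series" means these few. Any claim that something is new, unique, unknown or untested is made for them only; others in the source may bear on it.

Measured so far:
- compound 1, `Nc1nc(Cc2ccccc2)c(-c2ccccc2Br)n1CC(=O)Nc1ccccc1`, 5200 nM
- compound 2, `Cc1ccc(Cc2nc(N)n(CC(=O)Nc3ccccc3)c2-c2ccccc2Br)cc1`, 2500 nM
- compound 3, `CCCCCc1nc(N)n(CC(=O)Nc2ccc(C)cc2)c1-c1ccccc1Br`, 4300 nM

All three were tested in a functional assay on A-375 cells (Homo sapiens) for antiproliferative activity, read by MTT assay, with a stated time of 48 h; on this read-out higher numbers stand for weaker inhibition and lower numbers for stronger inhibition. Compound 3 gives a number that sits close to those of compound 1 and compound 2, with each gap inside the usual spread of repeat measurements, so the three cannot be ranked against one another. Going by the values given here, the only single-point change that can be sized is a 2.1-fold lower number from compound 1 to compound 2 (0.32 log units; beyond the scatter), a modest shift for a methyl in place of hydrogen on an aromatic carbon.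

The new compound, compound 4, is `Cc1ccc(NC(=O)Cn2c(N)nc(Cc3ccc(C(C)(C)C)cc3)c2-c2ccccc2Br)cc1`. Its difference from compound 3 is 4-(tert-butyl)phenyl in place of butyl on a saturated chain carbon bound to an aromatic carbon. Among the compounds with values here, no measured pair isolates this kind of change; compound 2 carries a benzyl-type group where compound 3 carries pentyl, but those two compounds also differ elsewhere, so their values can only be read side by side, not as a clean step. On that basis a small move toward a lower number is expected at most, a 1.4-fold lower number from compound 3 to compound 4 (0.16 log units; within the scatter), with a wide band of uncertainty. Compound 4 is estimated at 3000 nM, between 1200 nM and 8000 nM.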

Compound 4, half-maximal inhibitory concentration: 1400 nM
Compound 4: middle estimate off by 2.1-fold (0.33 log units), on the high side; the range from low to high includes it.
By their numbers in this assay, from the lowest: compounds 4, 2, 3 and 1 (each within the scatter of the next, the first and the last beyond it).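

In this assay, the step from a chain to a ring-bearing group is a 3.1-fold lower number from compound 3 to compound 4 (0.49 log units; beyond the scatter), so this position, a saturated chain carbon bound to an aromatic carbon, can take 4-(tert-butyl)phenyl in place of butyl and the number still falls. Going by these compounds alone, until now, the only step that could be sized was the much smaller change of a 2.1-fold lower number from compound 1 to compound 2 (0.32 log units; beyond the scatter), a methyl in place of hydrogen on an aromatic carbon, whereas this one swaps a whole open chain for a larger group holding a six-membered aromatic ring of carbon only. Both steps add carbon and both lower the number, though two steps are too few to make a rule, and nothing available explains why this larger group gives the lower number.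

This single step changes the ring and the tert-butyl together, so it cannot show how much of the shift belongs to each. On these data alone, how this position would respond to a longer chain than pentyl, or to a group carrying an amine or a carboxylic acid, remains open.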